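Cyclohexenone diesters: removing the epoxide ester

The compounds below may be only part of what the source reports. "The series", "measured", "known", "first", "only" and "open" are said of these compounds alone.

Measured compounds:
compound 1, `C/C=C(/C)C(=O)O[C@@H]1C=C(CO)C(=O)[C@@H](OC(=O)[C@]2(C)O[C@@H]2C)[C@@H]1C(C)C`: 2000 nM
compound 2, `C/C=C(/C)C(=O)O[C@@H]1C(=O)C(CO)=C[C@@H](OC(=O)/C(C)=C/C)[C@H]1C(C)C`: 2000 nM

In a functional assay on MDA-MB-231 cells (Homo sapiens) for cytotoxicity, read by XTT assay, with a stated time of 72 h (on this read-out lower numbers stand for stronger inhibition and higher numbers for weaker inhibition), compound 1 gives 2000 nM. In this assay compound 2 gives 2000 nM. The two numbers stand level at the digits shown and lie within the scatter, so no order between compound 1 and compound 2 can be read from them; no step between these two measured compounds has been worked out beyond this comparison.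

Compound 3, `C/C=C(/C)C(=O)O[C@@H]1C=C(CO)C(=O)[C@@H](O)[C@@H]1C(C)C`, has not yet been measured. Against compound 1 the change is hydrogen in place of (2,3-dimethyloxiran-2-yl)carbonyl on an oxygen on a saturated carbon. Neither measured compound offers a direct precedent for this change, as both keep two ester groups on the core. The step of a 2.5-fold higher number from compound 1 to compound 3 (0.40 log units; beyond the scatter) is expected to run toward weaker inhibition, beyond the scatter but not by a large amount. Compound 3 is estimated at 5000 nM, within a range of 1500 nM to 16000 nM.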

Compound 3, half-maximal inhibitory concentration: 6500 nM
Compound 3: the middle estimate sits 1.3-fold (0.11 log units) below what was measured, and the stated range covers the measured number.
By their numbers in this assay, from the lowest: compounds 1 and 2 (each within the scatter of the next); then compound 3.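

In this assay, hydrogen in place of (2,3-dimethyloxiran-2-yl)carbonyl on this oxygen gives a 3.3-fold higher number from compound 1 to compound 3 (0.51 log units; beyond the scatter) and leaves a free hydroxy group on the saturated carbon. Inhibition therefore remains measurable without this ester, at the cost of a modest step; compound 1 and compound 2 could not show this, as both keep two ester groups on the core. No measured evidence bears on what lies behind the step.

The compounds shown leave open whether the step follows from losing the three-membered ring or the whole ester, which an acetyl ester on this oxygen would help to separate. Also open, on these data alone, is how a methyl ether or an amine in place of the hydroxy group would read out on the core of compound 3.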